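Moving the Ring Nitrogen from Compound 2 to Compound 4

The source may report more compounds than this note shows. Statements on the series, on what has been measured and on what is new or still open speak of the compounds shown alone.

Of the compounds shown here, three built on one shared core have been tested in an assay on CHO cells for displacement of a labelled ligand from Alpha-2B adrenergic receptor (Homo sapiens); a lower number here means a stronger inhibitor, a higher number a weaker inhibitor. Compound 1 `CC(Oc1ccccc1-c1ccc([N+](=O)[O-])cc1)C1=NCCN1` gives 501 nM. Compound 2 `CC(Oc1ccccc1-c1ccncc1)C1=NCCN1` gives 2690 nM. Compound 3 `CC(Oc1ccccc1-c1ccccc1[N+](=O)[O-])C1=NCCN1` gives 1550 nM.

Among these three numbers, compound 2 has the highest. Compound 3 stands closest to it, and the gap between them falls within the usual scatter of repeated measurements, so no real difference between the two can be claimed. Compound 1 stands furthest from compound 2, with the smaller number, and that gap lies beyond the scatter.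

Compound 4 `CC(Oc1ccccc1-c1ccccn1)C1=NCCN1` has not yet been measured in this assay. It differs from compound 2 in one place: pyridin-2-yl in place of pyridin-4-yl on an aromatic carbon. The two compounds contain the same atoms, only joined differently.

Among the measured compounds shown here, no measured pair among the three compounds shows this particular change, so the data give no direct guide to its size or direction. With nothing pointing one way or the other, the expectation is a step that stays within the scatter. Compound 4 is estimated at 2000 nM, with a range from 600 nM to 7000 nM. This estimate means an expected step of a 1.3-fold lower number from compound 2 to compound 4 (0.13 log units; within the scatter), not beyond the scatter.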

Compound 4, inhibition constant: 3310 nM
Compound 4: the middle estimate sits 1.7-fold (0.22 log units) below what was measured; the range from low to high includes it.
By their numbers in this assay, from the lowest: compound 1; then compounds 3, 2 and 4 (each within the scatter of the next, the first and the last beyond it).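

Moving the ring nitrogen gives the first direct reading of a single change at this place, on an aromatic carbon ortho to a group of 8 heavy atoms: in this assay, pyridin-2-yl in place of pyridin-4-yl brings a 1.2-fold higher number from compound 2 to compound 4 (0.09 log units; within the scatter). This step lies within the scatter, so no real difference between compound 2 and compound 4 can be claimed, and for this pair the position of the nitrogen in the attached ring leaves no measurable mark on the number. No supporting evidence is available that could explain this result.

The compounds shown leave open whether a pyridin-3-yl group, a plain phenyl ring or a phenyl ring carrying an amine would give a number close to those of compound 2 and compound 4. They also leave open whether the same nitrogen move would stay this small on a different core or at a different receptor.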